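Fluoro gives way to nitro on a shared core

The compounds below may be only part of what the source reports. "The series", "measured", "known", "first", "only" and "open" are said of these compounds alone.

Of the compounds shown here, three sharing one core have been measured so far in a functional assay on Huh-7 cells (Homo sapiens) for cytotoxicity, with a stated time of 48 h; on this read-out higher numbers stand for weaker inhibition and lower numbers for stronger inhibition. Compound 1 `COc1cc(OC)c(C(=O)/C=C/c2ccccc2)c(OC)c1` gives 15500 nM, compound 2 `COc1cc(OC)c(C(=O)/C=C/c2ccc(Cl)cc2)c(OC)c1` gives 12700 nM, and compound 3 `COc1cc(OC)c(C(=O)/C=C/c2ccc(F)cc2)c(OC)c1` gives 14600 nM. Compound 3 therefore stands level with the other two, as its number lies within the usual scatter of both.

The next compound, compound 4 `COc1cc(OC)c(C(=O)/C=C/c2ccc([N+](=O)[O-])cc2)c(OC)c1`, carries nitro in place of fluoro on an aromatic carbon, para to a large group: nitro in place of fluoro on an aromatic carbon.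

Among the compounds with values here, three measured steps concern this same place on the molecule. Chloro in place of hydrogen gave a 1.2-fold lower number from compound 1 to compound 2 (0.09 log units; within the scatter), fluoro in place of hydrogen gave a 1.1-fold lower number from compound 1 to compound 3 (0.03 log units; within the scatter), and fluoro in place of chloro gave a 1.1-fold higher number from compound 2 to compound 3 (0.06 log units; within the scatter). All three lie within the scatter. None of them involves nitro, so they are an indirect guide and the range has to stay wide. Starting from compound 3 at 14600 nM, no step beyond the scatter is expected in this assay. The estimated step is a 1.1-fold lower number from compound 3 to compound 4 (0.05 log units; within the scatter). For compound 4 the estimated value is 13000 nM, with an expected range from 6000 nM to 28000 nM.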

Compound 4, half-maximal inhibitory concentration: 4900 nM
Beside the measured number, compound 4's estimate is 2.7-fold (0.42 log units) above it, outside the stated range (below it).
By their numbers in this assay, from the lowest: compound 4; then compounds 2, 3 and 1 (each within the scatter of the next).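

In this assay, this position proves able to shift the number after all: nitro in place of fluoro gives a 3.0-fold lower number from compound 3 to compound 4 (0.47 log units; beyond the scatter), nitro in place of chloro gives a 2.6-fold lower number from compound 2 to compound 4 (0.41 log units; beyond the scatter), and nitro in place of hydrogen gives a 3.2-fold lower number from compound 1 to compound 4 (0.50 log units; beyond the scatter), all modest but all beyond the scatter. Hydrogen, chloro and fluoro at this place stand within the scatter of one another, so nitro is the only one of the four groups that separates from the rest, and compound 4 has the lowest number of the set, with its steps to all three others beyond the scatter. The data offer no measurement that would explain why nitro behaves differently from the other three groups.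

Within the data shown here, with only one group standing apart, it remains open whether a nitrile or a trifluoromethyl at the same place would also lower the number, or whether an amine or a carboxylic acid would leave it level with compounds 1, 2 and 3. From the compounds shown here alone, it also remains open whether the step seen with nitro would carry over to other cell lines.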